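The source may report more compounds than this note shows. Statements on the series, on what has been measured and on what is new or still open speak of the compounds shown alone.

Measured so far:
- Compound 1 `CCOC(=O)C1=C(N/N=C(\c2ccc([N+](=O)[O-])cc2)N2CCN(c3ccc(F)cc3)CC2)Nc2[nH]nc(C)c2C1c1ccc(N(C)C)cc1` gives 87000 nM in a functional assay on HeLa cells (Homo sapiens) for inhibition, read by MTT assay, with a stated time of 48 h; a higher number here means a weaker inhibitor, a lower number a stronger inhibitor.
- Compound 2 `CCOC(=O)C1=C(N/N=C(/Cl)C#N)Nc2[nH]nc(C)c2C1c1ccc(N(C)C)cc1` gives 26200 nM in this assay.

Both compounds share the same core and differ only in the group attached to the amine nitrogen of that core. On the two numbers available, compound 2 has the lower value in this assay, and the gap to compound 1 lies beyond the usual scatter of this kind of measurement, so compound 2 is the stronger inhibitor of the two. Even so, both numbers sit at high concentrations, so neither compound is a potent inhibitor.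

The next compound, compound 3 `CCOC(=O)C1=C(N/N=C(/C#N)C(=O)OCC)Nc2[nH]nc(C)c2C1c1ccc(N(C)C)cc1`, keeps the core and the attachment point of compound 2 and changes only the group on the amine nitrogen: a group of 9 heavy atoms (5 carbon, 2 nitrogen, 2 oxygen; no ring) in place of a group of 5 heavy atoms (2 carbon, 2 nitrogen, 1 chlorine; no ring), on an amine nitrogen

Going by the values given here, no measured pair shows the effect of such a change, so the expectation rests on compound 2 alone. With both groups lacking rings and both small, the step from compound 2 to compound 3 in this assay is expected to stay within the scatter, a 1.1-fold higher number from compound 2 to compound 3 (0.06 log units; within the scatter). Compound 3 is therefore estimated at 30000 nM, with a likely range from 8000 nM to 110000 nM.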

Compound 3, half-maximal inhibitory concentration: 39200 nM
For compound 3 the middle estimate is 1.3-fold (0.12 log units) below the measured one; the measured number falls inside the stated range.
By their numbers in this assay, from the lowest: compounds 2 and 3 (each within the scatter of the next); then compound 1.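

At this amine nitrogen, a group of 5 heavy atoms (2 carbon, 2 nitrogen, 1 chlorine; no ring) can be exchanged for a group of 9 heavy atoms (5 carbon, 2 nitrogen, 2 oxygen; no ring) without a readable change in this assay, with a 1.5-fold higher number from compound 2 to compound 3 (0.17 log units; within the scatter). The entering group also has 4 hydrogen-bond acceptors in place of 2, so in this single pair neither the added heavy atoms nor the added acceptors move the number beyond the scatter, although one pair cannot establish a general rule for this position. No measurement at hand explains why these two groups read alike.

The compounds shown leave open how a carboxylic acid, a simple amine or a longer chain on this amine nitrogen would read in this assay. They also leave open whether the close reading of compound 2 and compound 3 would hold with a different group elsewhere on the shared core.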